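A few compounds are considered here, and "the series" means these few. Any claim that something is new, unique, unknown or untested is made for them only; others in the source may bear on it.

Within the data shown here, compound 2 `COc1cc(-c2nn(-c3ccc(NC(=O)c4cc(Cl)cc(Cl)c4)cc3)cc2-c2ccncc2)ccc1Cl` gives 12000 nM in a functional assay on SK-MEL-5 cells (Homo sapiens) for antiproliferative activity, read by sulforhodamine B assay, with a stated time of 48 h (on this read-out higher numbers stand for weaker inhibition and lower numbers for stronger inhibition), the higher of the two numbers measured so far, with compound 1 `COc1cc(-c2nn(-c3ccc(NC(=O)Nc4ccc(Cl)c(C(F)(F)F)c4)cc3)cc2-c2ccncc2)ccc1Cl` at 1570 nM. Compound 3 `COc1cc(-c2nn(-c3ccc(NC(=O)c4ccc(Cl)c(C(F)(F)F)c4)cc3)cc2-c2ccncc2)ccc1Cl` differs from compound 2 by 4-chloro-3-(trifluoromethyl)phenyl in place of 3,5-dichlorophenyl on a carbonyl carbon. Among the measured compounds shown here, the only measured step, a 7.6-fold higher number from compound 1 to compound 2 (0.88 log units; beyond the scatter), changed both the aryl group and the linker, urea to amide, so it bears on the change to compound 3 only in part. Restoring the aryl group while keeping the amide is expected to recover part of that step, so compound 3 is expected at 4500 nM, between 1200 nM and 15000 nM, an estimated step of a 2.7-fold lower number from compound 2 to compound 3 (0.43 log units; beyond the scatter).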

Compound 3, half-maximal inhibitory concentration: 1590 nM
For compound 3 the middle estimate is 2.8-fold (0.45 log units) above the measured one, within the range that was stated.
By their numbers in this assay, from the lowest: compounds 1 and 3 (each within the scatter of the next); then compound 2.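

In this assay the aryl group on the carbonyl carbon alone carries the change, with 4-chloro-3-(trifluoromethyl)phenyl giving a 7.5-fold lower number from compound 2 to compound 3 (0.88 log units; beyond the scatter), so the earlier step from compound 1 to compound 2 need not involve the linker. With this aryl group held constant, urea to amide gives a 1.0-fold higher number from compound 1 to compound 3 (0.01 log units; within the scatter), so the two linkers cannot be told apart here. No measurement at hand accounts for the preference between these aryl groups.

Still open, going by these compounds, is whether 3,5-dichlorophenyl would read the same on a urea. Also open, on these data alone, is how an aryl group carrying an amine or a carboxylic acid would fare on the carbonyl carbon.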